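The source may report more compounds than this note shows. Statements on the series, on what has been measured and on what is new or still open speak of the compounds shown alone.

In a functional assay on OVCAR-3 cells (Homo sapiens) for antiproliferative activity, read by sulforhodamine B assay, with a stated time of 72 h (on this read-out lower numbers stand for stronger inhibition and higher numbers for weaker inhibition), compound 1 (`C(=C/c1ccccc1)\C(=N\Nc1nncc2ccccc12)c1ccccc1`) gives 3.3 nM and compound 2 (`S=C(NNc1nncc2ccccc12)Nc1ccccc1`) gives 6 nM while compound 3 (`Fc1ccc(Nc2nncc3ccccc23)cc1`) gives 5.4 nM on the same read-out. Compound 3 thus lies within the scatter of both others, and the three cannot be ranked. Compound 4 (`N#Cc1ccc(Nc2nncc3ccccc23)cc1`) carries cyano in place of fluoro on an aromatic carbon, para to a large group (cyano in place of fluoro on an aromatic carbon). Among the compounds with values here, no two measured compounds differ in one place, so no measured step guides the expectation. Little change is expected in this assay and the expected step of a 1.5-fold higher number from compound 3 to compound 4 (0.17 log units; within the scatter) stays within the scatter. Compound 4 is estimated at 8 nM with an expected range from 2.5 nM to 30 nM in this read-out.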

Compound 4, half-maximal inhibitory concentration: 4.3 nM
Estimate against measurement, compound 4: 1.9-fold (0.27 log units) above; low and high end bracket the measured number.
By their numbers in this assay, from the lowest: compounds 1, 4, 3 and 2 (each within the scatter of the next).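

In this assay, the replacement of fluoro by cyano on an aromatic carbon, para to a large group, gives a 1.3-fold lower number from compound 3 to compound 4 (0.10 log units; within the scatter), the first single-place comparison available here. At this position, the two groups cannot be told apart on this read-out, even though cyano brings a triple bond and a hydrogen-bond acceptor that fluoro lacks. No measurement here bears on why the two groups read alike. From the compounds shown here alone, whether an amine, a carboxylic acid or a methoxy group at this position would also leave the number within the scatter remains open.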